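The source may hold more compounds than are shown below. What is called first, only, known or untested is meant among the compounds shown, and "the series" means these compounds.

Three measured compounds share one core and differ only in what sits on the aromatic carbon of the fused ring system. Compound 1 `CC#C[C@@H](CC(=O)O)c1ccc(OC[C@H]2COc3ccc(Cl)cc3O2)cc1` carries hydrogen there, compound 2 `CC#C[C@@H](CC(=O)O)c1ccc(OC[C@H]2COc3cc(F)c(Cl)cc3O2)cc1` carries fluoro and compound 3 `CC#C[C@@H](CC(=O)O)c1ccc(OC[C@H]2COc3cc(Cl)c(Cl)cc3O2)cc1` carries chloro. In a functional assay on HEK293 cells for agonist activity at Free fatty acid receptor 1 (Homo sapiens), read by fluorescence and calcium flux, with a stated time of 10 min (on this read-out higher numbers stand for larger maximal responses and lower numbers for smaller maximal responses), compound 1 gives 86%, compound 2 gives 46% and compound 3 gives 33%. Compound 3 thus stands lowest of the three: the step of a number 53 percentage points lower from compound 1 to compound 3 (beyond the scatter) is large, and the step of a number 13 percentage points lower from compound 2 to compound 3 (beyond the scatter) is modest but still beyond the scatter.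

Compound 4 `CC#C[C@@H](CC(=O)O)c1ccc(OC[C@H]2COc3cc(Br)c(Cl)cc3O2)cc1` continues this series. bromo in place of chloro on an aromatic carbon The change sits ortho to a chloro group, meta to a fused ring and para to a fused ring.

The most relevant measured step is a number 13 percentage points lower from compound 2 to compound 3 (beyond the scatter), a modest fall when one halogen replaced another; the larger falls a number 40 percentage points lower from compound 1 to compound 2 (beyond the scatter) and a number 53 percentage points lower from compound 1 to compound 3 (beyond the scatter) show that adding a halogen at this place lowers the response. A further modest fall, a number 9 percentage points lower from compound 3 to compound 4 (within the scatter), is therefore expected for compound 4.

Compound 4 is estimated to reach 24% in this assay, with a range from 10% to 40%.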

Compound 4, largest response reached (Emax), in percent of the reference or control that the assay uses: 82%
For compound 4 the middle estimate is 58 percentage points below the measured one; measured number above the stated range.
By their numbers in this assay, from the lowest: compound 3; then compound 2; then compounds 4 and 1 (each within the scatter of the next).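

The response at this aromatic carbon does not follow a single rule for halogens: fluoro and chloro gave lower numbers in this assay, but bromo breaks that pattern, with a number 49 percentage points higher from compound 3 to compound 4 (beyond the scatter) and a number 36 percentage points higher from compound 2 to compound 4 (beyond the scatter), both large steps. Set against hydrogen, bromo gives a number 4 percentage points lower from compound 1 to compound 4 (within the scatter), so carrying a halogen here does not by itself lower the response, and the exchange of a single atom can decide between a low and a high maximal response. Nothing available explains why bromo differs so sharply from chloro.

From the compounds shown here alone, it remains open whether iodo, methyl or methoxy on this carbon would give a response like that of bromo or like that of chloro. Also open, going by these compounds, is how bromo would behave without the chloro group that all four compounds carry.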